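The source may hold more compounds than are shown below. What is called first, only, known or untested is meant among the compounds shown, and "the series" means these compounds.

Measured compounds:
Compound 1, `O=S(=O)(Nc1ccc(-c2nc3ccccc3o2)cc1)c1cccs1`: > 100000 nM
Compound 2, `O=S(=O)(Nc1ccc(-c2nc3ccccc3o2)cc1)c1ccc(C(F)(F)F)cc1`: 94000 nM
Compound 3, `O=S(=O)(Nc1ccc(-c2nc3ccccc3o2)cc1)c1ccccc1Cl`: > 100000 nM

In an ADME assay on HEK293 cells (Homo sapiens) for cytotoxicity, read by resazurin assay, with a stated time of 48 h (a higher number here means that more compound is tolerated, a lower number that less compound is tolerated), compound 1 gives > 100000 nM, which is a limit of the assay and not a number. Compound 2 gives 94000 nM in this assay. Compound 3 gives > 100000 nM in this assay, again a limit and not a number. Compound 3 therefore stands at the edge of what the assay can report, and it is not alone there, since (the limit of > 100000 nM in this assay, at which 2 of the 3 values shown sit). Going by the values given here, the only step that touches the sulfonyl substituent is a step that the two limits leave unreadable from compound 1 to compound 3, and the two limits leave its size unreadable.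

Compound 4 is `Cc1ccc(S(=O)(=O)Nc2ccc(-c3nc4ccccc4o3)cc2)cc1`. It differs from compound 3 in one place: 4-methylphenyl in place of 2-chlorophenyl on a sulfonyl sulfur. Among the compounds with values here, no measured step speaks directly to this exchange, and the one step that changes the same position cannot be sized. What the data do show is that all three measured compounds sit at or close to the limit of the assay in this assay. Compound 4 is therefore expected to behave in the same way, with a step of an at least 1.0-fold lower number from compound 3 to compound 4 (0.02 log units; that floor lies within the scatter) from compound 3 that does not go beyond the scatter. The estimate for compound 4 in this assay is 95000 nM, with a range from 45000 nM to 200000 nM, and it is expected that the assay may again report only a limit.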

Compound 4, half-maximal cytotoxic concentration: 88000 nM
The estimate for compound 4 lay 1.1-fold (0.03 log units) above the measured number; the measured number falls inside the stated range.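

Compound 4 gives the sulfonyl substituent a second number that can be set directly beside another in this assay: methyl in place of trifluoromethyl on an aromatic carbon is a 1.1-fold lower number from compound 2 to compound 4 (0.03 log units; within the scatter), so this exchange shows no difference that can be told from the scatter. Against compound 3 and compound 1 only floors can be read, an at least 1.1-fold lower number from compound 3 to compound 4 (0.05 log units; that floor lies within the scatter) and an at least 1.1-fold lower number from compound 1 to compound 4 (0.05 log units; that floor lies within the scatter), and the true size of either step remains unknown. The values of compound 1 and compound 3 are limits of the assay and not numbers, and the step between those two still cannot be read: the limit of > 100000 nM in this assay, at which 2 of the 4 values shown sit.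

All the compounds shown carry an aromatic ring on the sulfonyl sulfur, so they leave open whether a longer alkyl chain there, or a ring bearing an amine or a carboxylic acid, would give a number in this assay that stands clearly apart from these. They also leave open whether any change to the shared core would move the value beyond the scatter.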